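The compounds below may be only part of what the source reports. "The series", "measured", "known", "first", "only" and "open" are said of these compounds alone.

In an ADME assay on MT4 cells (Homo sapiens) for cytotoxicity, read by MTT assay, with a stated time of 96 h (on this read-out lower numbers stand for higher toxicity in this test and higher numbers for lower toxicity in this test), compound 3 `FC(F)(F)c1ccc(NCc2cn(-c3ccccc3)nc2-c2ccc(C(F)(F)F)cc2)cc1` gives > 100000 nM as a limit and not a number. Compound 1 `FC(F)(F)c1ccc(-c2nn(-c3ccccc3)cc2CNc2ccc(Cl)cc2)cc1` gives > 100000 nM as a limit too. Compound 2 `Brc1ccc(NCc2cn(-c3ccccc3)nc2-c2ccccc2)cc1` carries no trifluoromethyl and gives > 100000 nM as a further limit. Compound 3 therefore stands with the other two at the limit of > 100000 nM in this assay, at which 3 of the 3 values shown sit, and has no exact value.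

The next structure is compound 4 `FC(F)(F)c1ccc(NCc2cn(-c3ccccc3)nc2-c2ccccc2)cc1`, and the change leading to it is hydrogen in place of trifluoromethyl on an aromatic carbon in which 4-(trifluoromethyl)phenyl becomes phenyl. Among the measured compounds shown here, the only measured step, a step that the two limits leave unreadable from compound 1 to compound 3, offers no size to carry over, and it concerns a different trifluoromethyl site. The best guide is therefore that all three measured compounds reached the same limit, with or without trifluoromethyl on this ring. The expected step, a number no higher from compound 3 to compound 4 (the limit leaves the size open), is none beyond the scatter in this assay and has no favoured direction. Compound 4 is estimated at 100000 nM in a range from 40000 nM to 100000 nM and is expected to be reported as a limit.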

Compound 4, half-maximal cytotoxic concentration: > 100000 nM
Compound 4 ended at the assay's limit; the forecaster's own chance of this, stated with the estimate: 80%; the middle value lies on the limit itself.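

In this assay the steps linking compound 4 to compound 2 and compound 3 cannot be read, because each pair has limits at both ends and not numbers: the limit of > 100000 nM in this assay, at which 4 of the 4 values shown sit.

The compounds shown leave open the exact value of any of these four compounds, and so whether any of these changes has an effect in this assay.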